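The compounds below may be only part of what the source reports. "The series", "measured", "known", "first", "only" and "open" are said of these compounds alone.

Compound 1 `O=C(Nc1ccc(C(F)(F)F)cc1)C1c2ccccc2CCN1C(=O)c1ccc(Cl)cc1`: 4200 nM
Compound 2 `O=C(Nc1ccc(C(F)(F)F)cc1)c1nccc2ccccc12`: > 10000 nM

Of the compounds shown here, two have so far been tested in a functional assay on NUGC-3 cells (Homo sapiens) for inhibition, read by sulforhodamine B assay, with a stated time of 48 h; on this read-out lower numbers stand for stronger inhibition of growth and higher numbers for weaker inhibition of growth. Compound 1 `O=C(Nc1ccc(C(F)(F)F)cc1)C1c2ccccc2CCN1C(=O)c1ccc(Cl)cc1` gives 4200 nM in this assay. Compound 2 `O=C(Nc1ccc(C(F)(F)F)cc1)c1nccc2ccccc12` returns only a limit, > 10000 nM, which is not a number. Compound 2 therefore stands at the limit of > 10000 nM in this assay, at which 1 of the 2 values shown sits, and no real value for it is known.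

Compound 3 `O=C(Nc1ccc(O)cc1)c1nccc2ccccc12` has not yet been measured in this assay. It differs from compound 2 by hydroxy in place of trifluoromethyl on an aromatic carbon. Going by the values given here, no measured step between two compounds that differ in one place is available, so the size of this change cannot be read from the data, and the starting point itself is only a limit. Compound 3 is expected to fall near 15000 nM in this assay, somewhere between 4000 nM and 50000 nM. The expected step is a step that the limit leaves unreadable from compound 2 to compound 3, an estimate that rests on a limit rather than a number and carries a real chance that this assay again reports only a limit.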

Compound 3, concentration for 50% growth inhibition: > 10000 nM
Compound 3 was reported as a limit; the forecaster's own chance of this, stated with the estimate: 60%; the middle value is on the limit's open side.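

No step can be read from compound 2 to compound 3, since this assay reports each of them only as a limit and not as a number: the limit of > 10000 nM in this assay, at which 2 of the 3 values shown sit.

The compounds shown leave open what hydroxy in place of trifluoromethyl on an aromatic carbon does to growth inhibition.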